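From furan-2-yl to thiophen-2-yl in a growth assay

The source may report more compounds than this note shows. Statements on the series, on what has been measured and on what is new or still open speak of the compounds shown alone.

Compound 1 `c1ccc(-c2cc(-c3cccnc3)nc(-c3ccccn3)c2)cc1`: 44.8 ug/mL
Compound 2 `c1ccc(-c2cc(-c3ccco3)cc(-c3ccccn3)n2)nc1`: 0.22 ug/mL

In a functional assay on A549 cells (Homo sapiens) for antiproliferative activity (a higher number here means a weaker inhibitor of growth, a lower number a stronger inhibitor of growth), compound 1 gives 44.8 ug/mL and compound 2 gives 0.22 ug/mL, the lower of the two numbers. The gap between these two compounds lies far beyond the scatter. Compound 3 `c1ccc(-c2cc(-c3cccs3)cc(-c3ccccn3)n2)nc1` has thiophen-2-yl in place of furan-2-yl on an aromatic carbon, opposite the ring nitrogen: thiophen-2-yl in place of furan-2-yl on an aromatic carbon. For the measured compounds named here, no measured pair shows this exchange, so the expectation rests on compound 2 at 0.22 ug/mL and the closely matched groups. No change beyond the scatter is expected in this assay, with any drift towards a slightly higher number. The expected step is a 1.8-fold higher number from compound 2 to compound 3 (0.26 log units; within the scatter). For compound 3 the estimated value is 0.4 ug/mL, within an expected range of 0.08 ug/mL to 2.5 ug/mL.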

Compound 3, concentration for 50% growth inhibition: 0.44 ug/mL
Compound 3: middle estimate off by 1.1-fold (0.04 log units), on the low side, within the range that was stated.
By their numbers in this assay, from the lowest: compounds 2 and 3 (each within the scatter of the next); then compound 1.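

In this assay, thiophen-2-yl in place of furan-2-yl on this aromatic carbon, opposite the ring nitrogen, gives a 2.0-fold higher number from compound 2 to compound 3 (0.30 log units; within the scatter), so this position accepts the exchange of oxygen for sulfur in the five-membered aromatic ring without a change beyond the scatter. No evidence is available that bears on this result. Still open, on these data alone, is how an open-chain amine or a morpholine ring at this position would read in this assay, and what a carboxylic acid on either pyridin-2-yl group would do.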